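This account rests on a few compounds, and the source may have more. Where it says the series, first, only, none or still open, it means among the compounds named here.

Measured so far:
Compound 1, `O=C(NCCCCn1cccn1)c1cccc(C2SCC(=O)N2c2ccccn2)c1`, gives 88.9 mL.min-1.g-1 in an ADME assay on microsomes from liver (Canis lupus familiaris) for metabolic stability, read by LC-MS, using NADPH, with a stated time of 10 min, tested at 0.1 uM; on this read-out higher numbers stand for fast clearance and lower numbers for slow clearance.
Compound 2, `O=C(NCCCCc1ccccc1)c1cccc(C2SCC(=O)N2c2cccc(F)c2)c1`, gives 837 mL.min-1.g-1 in this assay.
Compound 3, `COc1ccccc1N1C(=O)CSC1c1cc(F)cc(C(=O)NCCCCc2ccccc2)c1`, gives 2170 mL.min-1.g-1 in this assay.

Among these three numbers compound 2 stands second highest. Its nearest neighbour is compound 3, whose number lies beyond the scatter above it, and its furthest is compound 1, whose number lies well below, also beyond the scatter.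

Compound 4, `O=C(NCCCCc1ccccc1)c1cccc(C2SCC(=O)N2c2ccccc2F)c1`, has not yet been measured. It differs from compound 2 in one place: 2-fluorophenyl in place of 3-fluorophenyl on an amide-type nitrogen in a ring. Among the compounds with values here, no measured pair shows this kind of change, so there is no direct guide to its size. Compound 4 is expected to give a number close to that of compound 2, with the step of a 1.2-fold lower number from compound 2 to compound 4 (0.08 log units; within the scatter) lying within the scatter. The estimated value for compound 4 is 700 mL.min-1.g-1, in a range from 300 mL.min-1.g-1 to 1600 mL.min-1.g-1.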

Compound 4, intrinsic clearance in microsomes: 815 mL.min-1.g-1
The estimate for compound 4 lay 1.2-fold (0.07 log units) below the measured number; measured number inside the range.
By their numbers in this assay, from the lowest: compound 1; then compounds 4 and 2 (each within the scatter of the next); then compound 3.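

In this assay, 2-fluorophenyl in place of 3-fluorophenyl on the amide-type nitrogen gives a 1.0-fold lower number from compound 2 to compound 4 (0.01 log units; within the scatter). Within the data shown here, this is the first direct test of this position: with the rest of the molecule the same, the two fluorophenyl groups cannot be told apart by intrinsic clearance. Open, on these data alone, is whether a phenyl ring carrying a nitrile or an amine instead of fluorine would also stay within the scatter of compound 2, and whether the same swap would give a similar result with the pyrazole chain of compound 1. Nothing shown here explains why the two numbers match.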